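Methoxy for tert-butoxycarbonyl on the quaternary propyl chain

The source may report more compounds than this note shows. Statements on the series, on what has been measured and on what is new or still open speak of the compounds shown alone.

compound 1, `CC(C)(C)OC(=O)CCC[N+]1(C)CCc2c(sc(NC(=O)Nc3ccc(Cl)cc3)c2C(N)=O)C1`: 250 nM in a functional assay (strain AB) with Danio rerio as the target, read by microscopy, with a stated time of 1 h; on this read-out lower numbers stand for an effect already at smaller amounts and higher numbers for an effect only at larger amounts of compound
compound 2, `CC(C)(C)OC(=O)N1CCc2c(sc(NC(=O)Nc3ccc(Cl)cc3)c2C(N)=O)C1`: a limit of this assay, > 25000 nM
compound 3, `CC(C)(C)OC(=O)CN1CCc2c(sc(NC(=O)Nc3ccc(Cl)cc3)c2C(N)=O)C1`: a limit of this assay, > 25000 nM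

Among the measured compounds shown here, compound 1 is the only member of the series with a number in this assay; the other two values are limits (the limit of > 25000 nM in this assay, at which 2 of the 3 values shown sit). The step that the two limits leave unreadable from compound 2 to compound 3 is therefore not readable. Compound 4, `COCCC[N+]1(C)CCc2c(sc(NC(=O)Nc3ccc(Cl)cc3)c2C(N)=O)C1`, keeps the charged ring nitrogen and the propyl chain of compound 1 and differs by methoxy in place of tert-butoxycarbonyl on a saturated chain carbon, three bonds along the chain from an amine nitrogen in a ring. For the measured compounds named here, no measured step tests this exchange, as compound 2 and compound 3 both lack the charged nitrogen and the chain. The step from compound 1 is expected to stay within the scatter or to be a small loss, a 1.6-fold higher number from compound 1 to compound 4 (0.20 log units; within the scatter). Compound 4 is therefore estimated at 400 nM, between 100 nM and 2500 nM.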

Compound 4, half-maximal effective concentration: 480 nM
Compound 4: middle estimate off by 1.2-fold (0.08 log units), on the low side; the measured number falls inside the stated range.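

In this assay, replacing tert-butoxycarbonyl with methoxy on the propyl chain gives a 1.9-fold higher number from compound 1 to compound 4 (0.28 log units; within the scatter). With the charged ring nitrogen and the propyl chain kept, tert-butoxycarbonyl is therefore not required at this place for a measurable value. Compound 2 and compound 3 stay limits, not numbers, and the step between them cannot be read: the limit of > 25000 nM in this assay, at which 2 of the 4 values shown sit.

From the compounds shown here alone, whether the charged nitrogen, the chain or both separate compound 1 and compound 4 from those limits remains open. So does whether a carboxylic acid, an amine or a longer chain at this place keeps the value.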